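The compounds below may be only part of what the source reports. "The series", "measured", "known", "first", "only" and "open" are said of these compounds alone.

Among the measured compounds shown here, in a functional assay on 786-0 cells (Homo sapiens) for inhibition, read by sulforhodamine B assay, with a stated time of 48 h (a higher number here means a weaker inhibitor of growth, a lower number a stronger inhibitor of growth), compound 1 (`S=C(N/N=C/c1cccs1)Nc1ccccc1`) gives 50400 nM and so stands highest of the two numbers measured so far. Compound 2 (`S=C(N/N=C/c1cccs1)Nc1cccnc1`) gives 5600 nM as the lower number, and the gap between the two lies beyond the usual scatter. Compound 3 (`S=C(N/N=C/c1cccs1)Nc1ccc(Br)cc1`) is still unmeasured. It keeps the core of compound 1 and carries bromo in place of hydrogen on an aromatic carbon, para to a large group (bromo in place of hydrogen on an aromatic carbon). For the measured compounds named here, no measured pair shows a change of this kind, so any expectation here is loose. Since compound 1 gives the higher number (50400 nM), a moderate move towards a lower number is expected, though it may not clear the scatter. The expected step is a 2.8-fold lower number from compound 1 to compound 3 (0.45 log units; beyond the scatter) in this assay as an estimate only. Compound 3 is estimated at 18000 nM with an expected range (5000 nM to 55000 nM).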

Compound 3, concentration for 50% growth inhibition: 4500 nM
Compound 3: middle estimate off by 4.0-fold (0.60 log units), on the high side; measured number outside the range, below it.
By their numbers in this assay, from the lowest: compounds 3 and 2 (each within the scatter of the next); then compound 1.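

In this assay, bromo in place of hydrogen on an aromatic carbon, para to a large group, gives an 11-fold lower number from compound 1 to compound 3 (1.05 log units; beyond the scatter), a large step and the first change at a single place that can be read among these compounds. It shows that this position on the six-membered aromatic ring of carbon only is not indifferent to substitution: one heavy atom, with no ring and no net charge, moves the number well beyond the scatter. Nothing measured here bears on the reason for this step.

The compounds shown leave open whether a fluoro, a methoxy or an amine at this place would move the number as far as bromo does. They also leave open whether the step belongs to this place alone or would appear with bromo elsewhere on that ring.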